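Removing a Methyl from the Aryl Ketone Tail

The source may report more compounds than this note shows. Statements on the series, on what has been measured and on what is new or still open speak of the compounds shown alone.

Of the compounds shown here, three share a core and have been tested in an ADME assay on HEK293 cells (Homo sapiens) for antiproliferative activity, read by MTT assay, with a stated time of 24 h; a lower number here means a stronger inhibitor, a higher number a weaker inhibitor. Compound 1 `COc1ccc(-c2cc(/C=C/C(=O)c3ccccc3)nc3cc(-c4ccccc4)nn23)cc1` gives 53200 nM; compound 2 `COc1cc(-c2cc(C(=O)/C=C/c3ccc(Cl)cc3)nc3cc(-c4ccccc4)nn23)cc(OC)c1OC` gives 53900 nM; compound 3 `COc1cc(-c2cc(/C=C/C(=O)c3ccc(C)cc3)nc3cc(-c4ccccc4)nn23)cc(OC)c1OC` gives 50400 nM. All three numbers sit within the scatter of one another, so compound 3 cannot be told apart from compounds 1 and 2 in this assay.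

Compound 4 `COc1cc(-c2cc(/C=C/C(=O)c3ccccc3)nc3cc(-c4ccccc4)nn23)cc(OC)c1OC` differs from compound 3 by hydrogen in place of methyl on an aromatic carbon. Within the data shown here, the only step on record, a 1.1-fold lower number from compound 2 to compound 3 (0.03 log units; within the scatter), alters a different part of the molecule, and the three measured values give no hint of any trend. No step beyond the scatter is therefore expected, and the estimated change a 1.0-fold higher number from compound 3 to compound 4 (0.01 log units; within the scatter) stays flat. Compound 4 is estimated at 52000 nM, ranging from 26000 nM to 104000 nM.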

Compound 4, half-maximal inhibitory concentration: >= 100000 nM
Compound 4 was reported as a limit; the forecaster's own chance of this, stated with the estimate: 10%; middle value at least 1.9-fold (0.28 log units) away from the limit.
By their numbers in this assay, from the lowest: compounds 3, 1 and 2 (each within the scatter of the next). At a limit, above all of these: compound 4.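

Compound 4 is reported only as a limit: the limit of >= 100000 nM in this assay, at which 1 of the 4 values shown sits. Replacing the methyl with hydrogen on the 4-methylphenyl gives an at least 1.9-fold higher number from compound 3 to compound 4 (0.29 log units; that floor lies within the scatter), so even this minimum does not show that the change matters. The swap to 2-benzoylethenyl gives an at least 1.8-fold higher number from compound 2 to compound 4 (0.26 log units; that floor lies within the scatter), and the swap to 3,4,5-trimethoxyphenyl gives an at least 1.8-fold higher number from compound 1 to compound 4 (0.27 log units; that floor lies within the scatter), which are also minimums rather than measured sizes.

As far as these compounds go, the true size of all three steps remains open. So does what a methoxy, an amine or a carboxylic acid on this same aromatic carbon would do to the number.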